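Cytotoxicity notes on compounds 1 to 4

This account rests on a few compounds, and the source may have more. Where it says the series, first, only, none or still open, it means among the compounds named here.

Measured so far:
compound 1 `C#CCN(c1nc(-c2cccc(Br)c2)no1)C1CCCCC1`, 53.5 ug/mL
compound 2 `CC(=O)OC[C@H]1O[C@H](OC[C@@H](Cn2cc(CN(c3nc(-c4cccc([N+](=O)[O-])c4)no3)C3CCCCC3)nn2)OC(C)=O)C=C[C@@H]1OC(C)=O`, > 200 ug/mL
compound 3 `CC(=O)OC[C@H]1O[C@H](OC[C@H](Cn2cc(-c3ccc(-c4noc(NC5CCCCC5)n4)cc3)nn2)OC(C)=O)C=C[C@@H]1OC(C)=O`, 79.8 ug/mL

In an ADME assay on HepG2 cells (Homo sapiens) for cytotoxicity, read by MTT assay, with a stated time of 48 h (a lower number here means that less compound is tolerated, a higher number that more compound is tolerated), compound 1 gives 53.5 ug/mL and compound 3 gives 79.8 ug/mL. For compound 2 the read-out is only a limit, > 200 ug/mL, which is the limit of > 200 ug/mL in this assay, at which 1 of the 3 values shown sits. No number therefore places compound 2 against the other two. Compound 4 `CC(=O)OC[C@H]1O[C@H](OC[C@@H](Cn2cc(CN(c3nc(-c4cccc(C)c4)no3)C3CCCCC3)nn2)OC(C)=O)C=C[C@@H]1OC(C)=O` differs from compound 2 by methyl in place of nitro on an aromatic carbon. Among the measured compounds shown here, no measured pair shows this change, and compound 2 itself is known only as a limit. The expected step is a modest move toward a lower tolerated concentration, possibly none beyond the scatter, an at least 1.3-fold lower number from compound 2 to compound 4 (0.12 log units; that floor lies within the scatter). Compound 4 is estimated at 150 ug/mL, expected between 60 ug/mL and 250 ug/mL.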

Compound 4, half-maximal cytotoxic concentration: 39.2 ug/mL
Compound 4: middle estimate off by 3.8-fold (0.58 log units), on the high side, and the stated range ends above it.
By their numbers in this assay, from the lowest: compounds 4, 1 and 3 (each within the scatter of the next, the first and the last beyond it). At a limit, above all of these: compound 2.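

Among the compounds shown here, replacing 3-nitrophenyl with 3-methylphenyl gives the first readable step at this place on the aromatic ring in this assay, and it lies beyond the scatter: an at least 5.1-fold lower number from compound 2 to compound 4 (0.70 log units; beyond the scatter). This shows that the substituent at this position matters in this series, and the size given is only a floor. Compound 2 is known only as a limit: the limit of > 200 ug/mL in this assay, at which 1 of the 4 values shown sits.

As far as these compounds go, on this core, only nitro and methyl appear at this position, so where an amine or a carboxylic acid there would fall remains open. From the compounds shown here alone, whether the same change gives a similar step on the core of compound 1 or compound 3 also remains open.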